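Replacing anilino with cyclopropylamino on the shared core

The source may hold more compounds than are shown below. What is called first, only, known or untested is meant among the compounds shown, and "the series" means these compounds.

In a functional assay on K562 cells (Homo sapiens) for antiproliferative activity, read by MTT assay, with a stated time of 48 h (a lower number here means a stronger inhibitor, a higher number a weaker inhibitor), compound 1 `O=C(CCCCCCn1cc(Nc2ncc(Cl)c(Nc3cccc(Cl)c3)n2)cn1)NO` gives 380 nM while compound 2 `CNc1nc(Nc2cnn(CCCCCCC(=O)NO)c2)ncc1Cl` gives 590 nM and compound 3 `O=C(CCCCCCn1cc(Nc2ncc(Cl)c(Nc3ccccc3)n2)cn1)NO` gives 420 nM, so compound 3 stands among three values that lie within the usual scatter of one another and cannot be ranked. Compound 4 `O=C(CCCCCCn1cc(Nc2ncc(Cl)c(NC3CC3)n2)cn1)NO` differs from compound 3 in one place: cyclopropyl in place of phenyl on a nitrogen on an aromatic ring. In words, this is cyclopropyl in place of phenyl on a nitrogen on an aromatic ring, or anilino to cyclopropylamino. Two measured steps changed the group on that same nitrogen. Phenyl in place of methyl gave a 1.4-fold lower number from compound 2 to compound 3 (0.15 log units; within the scatter), and methyl in place of 3-chlorophenyl gave a 1.6-fold higher number from compound 1 to compound 2 (0.19 log units; within the scatter). Within the data shown here, both are small, although neither involves cyclopropyl, so no measurement yet shows that group directly. A change beyond the scatter in this assay is therefore not expected. The expected step is a 1.2-fold higher number from compound 3 to compound 4 (0.08 log units; within the scatter), which would be too small to read as a real difference. For compound 4 the estimated value is 500 nM, with an expected range from 260 nM to 950 nM.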

Compound 4, half-maximal inhibitory concentration: 380 nM
Compound 4: middle estimate off by 1.3-fold (0.12 log units), on the high side, within the range that was stated.
By their numbers in this assay, from the lowest: compounds 1, 4, 3 and 2 (each within the scatter of the next).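

In this assay, this position accepts a three-membered non-aromatic ring as readily as the groups seen earlier: cyclopropyl in place of phenyl on the nitrogen gives a 1.1-fold lower number from compound 3 to compound 4 (0.04 log units; within the scatter) and cyclopropyl in place of methyl gives a 1.6-fold lower number from compound 2 to compound 4 (0.19 log units; within the scatter) on the same nitrogen. Cyclopropyl in place of 3-chlorophenyl gives no change at the digits printed from compound 1 to compound 4 (within the scatter) on this nitrogen. Methyl, phenyl, 3-chlorophenyl and now cyclopropyl therefore cannot be told apart here, and no measurement is available to explain this flat result. The compounds shown leave open whether an amine, a carboxylic acid or a longer carbon chain attached to this nitrogen would move the number beyond the scatter. They also leave open whether these four compounds would stay this close in any other test.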